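Replacing pyridin-2-yl in compound 2

A few compounds are considered here, and "the series" means these few. Any claim that something is new, unique, unknown or untested is made for them only; others in the source may bear on it.

Measured in a physicochemical assay for lipophilicity, at pH 7.4; a lower number here means a more polar compound, a higher number a more lipophilic compound:
- compound 1 `O=C(NC1CC1)C1CCN(c2cnccc2-c2ccccn2)CC1` gives 1.3
- compound 2 `CN(C)C(=O)C1CCN(c2cnccc2-c2ccccn2)CC1` gives 1.2

Of these two measured compounds, compound 2 stands at 1.2, with compound 1 close enough that the gap is within the scatter. Compound 3 `Cc1cnn(-c2ccncc2N2CCC(C(=O)N(C)C)CC2)c1` carries one change from compound 2: 4-methyl-1H-pyrazol-1-yl in place of pyridin-2-yl on an aromatic carbon. The new group, 4-methyl-1H-pyrazol-1-yl, sits on an aromatic carbon, opposite the ring nitrogen. Within the data shown here, the only measured step, a number 0.10 log units lower from compound 1 to compound 2 (within the scatter), concerns a carbonyl carbon, elsewhere in the structure. Among the measured compounds shown here, it therefore gives little guidance on the size of this change, and no step has been measured at this place. In this assay the expected step is small, a number 0.20 log units higher from compound 2 to compound 3 (within the scatter), and no move beyond the scatter is expected. For compound 3 the estimate is 1.4, with an expected range of 0.9 to 1.9.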

Compound 3, distribution coefficient: 1.6
For compound 3 the middle estimate is 0.20 log units below the measured one; the range from low to high includes it.
By their numbers in this assay, from the lowest: compounds 2, 1 and 3 (each within the scatter of the next, the first and the last beyond it).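

On the aromatic carbon opposite the ring nitrogen, 4-methyl-1H-pyrazol-1-yl in place of pyridin-2-yl gives the first step read at this position in this assay: a number 0.40 log units higher from compound 2 to compound 3 (beyond the scatter). Unlike the only earlier step, at the carbonyl carbon, this one lies beyond the scatter, so the read-out responds to this ring exchange even though the two groups match in heavy-atom count and neither carries a net charge. Nothing available explains the size or direction of this step.

Still open, from the compounds shown here alone, is whether the step follows from the methyl or from the five-membered ring itself, which an unsubstituted 1H-pyrazol-1-yl at this place would separate. Also open, going by these compounds, are whether the step carries over to the cyclopropylamino amide of compound 1 and how an amine or a carboxylic acid on this carbon would read in this assay.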